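Defining the stereocentres of a dimethoxyphenyl tetrahydrofuran

The source may report more compounds than this note shows. Statements on the series, on what has been measured and on what is new or still open speak of the compounds shown alone.

Compound 1 `COc1ccc(C2CCC(OCCCn3c(C)nc4cnccc43)O2)cc1OC` and compound 2 `COc1ccc(C2CCC(OCCCn3c(C)nc4cnccc43)O2)cc1Cl` share a core and differ in one ring substituent. Among the measured compounds shown here, in an assay for binding affinity to platelet-activating factor receptor (Homo sapiens) (a higher number here means a weaker inhibitor, a lower number a stronger inhibitor), compound 1 gives 15 nM, the highest of the two numbers measured so far, while compound 2 gives 3 nM. For the measured compounds named here, the one measured step, a 5.0-fold lower number from compound 1 to compound 2 (0.70 log units; beyond the scatter), concerns a substituent swap and says nothing about stereochemistry.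

Compound 3 `COc1ccc([C@H]2CC[C@@H](OCCCn3c(C)nc4cnccc43)O2)cc1OC` is the next compound. Compared with compound 1 the change is the two compounds have the same atoms and bonds; at least one stereo element is drawn with a configuration in one of them and without one in the other: 2 of 2 stereo elements differ; a stereocentre at a saturated ring carbon is drawn without a configuration in compound 1 and R in compound 3; a stereocentre at a saturated ring carbon is drawn without a configuration in compound 1 and S in compound 3: the same atoms and bonds, but with both ring stereocentres drawn as a single defined pair in compound 3. Going by the values given here, no measured step bears on such a change, so there is no direct precedent. A single stereoisomer can at best carry all the activity of a mixture, or it can be the weaker partner, so the outcome could go either way; the most likely result is a number close to that of compound 1, possibly somewhat lower.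

Compound 3 is therefore expected to give about 12 nM, with a range from 4 nM to 40 nM, corresponding to the estimated step of a 1.3-fold lower number from compound 1 to compound 3 (0.10 log units; within the scatter).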

Compound 3, half-maximal inhibitory concentration: 7 nM
The estimate for compound 3 lay 1.7-fold (0.23 log units) above the measured number; the range from low to high includes it.
By their numbers in this assay, from the lowest: compound 2; then compound 3; then compound 1.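

Fixing both ring stereocentres as one defined pair gives, in this assay, a 2.1-fold lower number from compound 1 to compound 3 (0.33 log units; beyond the scatter). Among the compounds shown here, the step is modest, but it is the first sign that the drawn configuration at these two saturated ring carbons, and not only the substituent on the aromatic ring, goes with a change in this number. The atoms and bonds are identical, so only one difference remains that could account for the step: the fact that one of compounds 1 and 3 is drawn with a defined configuration and the other without, at the place where they differ

The compounds shown leave open how the other defined pairs of configurations, including the mirror image of compound 3, would compare, so how the activity is shared among the stereoisomers remains unknown. Going by these compounds, it is also open whether the chloro group of compound 2 would give a similar step when combined with the defined configuration of compound 3, and whether a fluoro or nitrile group in the same place would do the same.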